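The compounds below may be only part of what the source reports. "The series", "measured", "known", "first", "only" and "open" are said of these compounds alone.

The series shares the core of compound 1 `CC(C)CCn1nc(-c2cccs2)c(O)c(C2=NS(=O)(=O)c3ccccc3N2)c1=O`, and three of its members have been measured in an ADME assay on Huh-7 cells (Homo sapiens) for cytotoxicity, with a stated time of 72 h; on this read-out higher numbers stand for lower toxicity in this test and lower numbers for higher toxicity in this test. For compound 1 the reading in this assay is a limit of the test, > 33000 nM. Compound 2 `CC(C)CCn1nc(-c2cccs2)c(O)c(C2=NS(=O)(=O)c3cc(OC(C)C(N)=O)ccc3N2)c1=O` carries 1-carbamoylethoxy in place of hydrogen on an aromatic carbon and gives 68000 nM in this assay. Compound 3 `CC(C)CCn1nc(-c2cccs2)c(O)c(C2=NS(=O)(=O)c3cc(OC(C)(C)C(N)=O)ccc3N2)c1=O` carries 1-carbamoyl-1-methylethoxy in place of hydrogen on an aromatic carbon; its reading in this assay is again a limit of the test, > 33000 nM. Compound 3 thus stands on a limit only, and a second value in the set is also a limit (the limit of > 33000 nM in this assay, at which 2 of the 3 values shown sit). The steps between the measured compounds are a step that the limit leaves unreadable from compound 1 to compound 2, a step that the two limits leave unreadable from compound 1 to compound 3 and a step that the limit leaves unreadable from compound 2 to compound 3; none of them can be sized.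

Compound 4 `CC(C)CCn1nc(-c2cccs2)c(O)c(C2=NS(=O)(=O)c3cc(OCC(=O)NO)ccc3N2)c1=O` differs from compound 3 by (hydroxycarbamoyl)methyl in place of 1-carbamoyl-1-methylethyl on an oxygen on an aromatic ring. For the measured compounds named here, the measured steps bear on this change only in that not one of them is readable, and compound 2, with 68000 nM, supplies the sole number in the set. No step beyond the scatter is expected, so the step from compound 3 to compound 4 is estimated as a step that the limit leaves unreadable from compound 3 to compound 4, with a fair chance that the assay again returns only a limit. Compound 4 is expected to read 50000 nM in this assay, within 20000 nM to 150000 nM.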

Compound 4, half-maximal cytotoxic concentration: > 33000 nM
Compound 4 was reported as a limit (the forecaster's own chance of this, stated with the estimate: 60%); the middle value is on the limit's open side.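

Compound 4 reads > 33000 nM in this assay, which is a limit of the test. No step to compound 4 from compound 1, compound 2 or compound 3 can be read: the limit of > 33000 nM in this assay, at which 3 of the 4 values shown sit.

The compounds shown leave open whether (hydroxycarbamoyl)methoxy and 1-carbamoyl-1-methylethoxy differ at all in this assay, and how either compares with hydrogen on the aromatic carbon.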